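Moving the Amine Along a Branched Chain

A few compounds are considered here, and "the series" means these few. Any claim that something is new, unique, unknown or untested is made for them only; others in the source may bear on it.

Measured so far:
Compound 1, `c1ccc(CNCCCCN(C[C@H]2Cc3ccccc3CN2)[C@H]2CCCc3cccnc32)cc1`. In a functional assay on cells for agonist activity at C-X-C chemokine receptor type 4 (Homo sapiens), read by fluorescence and calcium flux, with a stated time of 90 s (on this read-out lower numbers stand for an effect already at smaller amounts and higher numbers for an effect only at larger amounts of compound), compound 1 gives > 30000 nM, a limit of the assay rather than a number.
Compound 2, `CC(C)(CCN)CN(C[C@H]1Cc2ccccc2CN1)[C@H]1CCCc2cccnc21`. In this assay compound 2 gives > 30000 nM, again a limit of the assay.

Compound 2 therefore stands at the limit of this assay, with no finished number of its own. For the measured compounds named here, the one step measured between the two compounds, a step that the two limits leave unreadable from compound 1 to compound 2, cannot be read, because of the limit of > 30000 nM in this assay, at which 2 of the 2 values shown sit.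

Compound 3, `CC(C)(CN)CCN(C[C@H]1Cc2ccccc2CN1)[C@H]1CCCc2cccnc21`, is built from the same atoms as compound 2, joined differently: a group of 6 heavy atoms (5 carbon, 1 nitrogen; no ring) in place of a group of 6 heavy atoms (5 carbon, 1 nitrogen; no ring), on a saturated chain carbon bound to an amine nitrogen. Going by the values given here, the single measured step bears on it only in a loose sense, since it is itself unreadable, so no direction of change in this assay can be taken from the measurements. Among the compounds with values here, what the numbers do show is that both values so far sit at the limit. Compound 3 is therefore expected to give 30000 nM in this assay, within 10000 nM to 100000 nM, which corresponds to an expected step of a number no higher from compound 2 to compound 3 (the limit leaves the size open), and most likely the assay will again report only a limit.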

Compound 3, half-maximal effective concentration: > 30000 nM
Compound 3: only a limit was reported; the forecaster's own chance of this, stated with the estimate: 80%; the middle value lies on the limit itself.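

In this assay compound 3 gives > 30000 nM, again a limit and not a number. The steps among compound 1, compound 2 and compound 3 therefore cannot be read: the limit of > 30000 nM in this assay, at which 3 of the 3 values shown sit. The compounds shown leave open how far any of these three side chains stands from a finished value in this assay, and which of them would come closest.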